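Amide aryl swap on the shared core

This account rests on a few compounds, and the source may have more. Where it says the series, first, only, none or still open, it means among the compounds named here.

Compound 1 `COc1cc(Cl)cc(-c2nn(-c3cccc(NC(=O)c4ccc(Cl)c(Cl)c4)c3)cc2-c2ccncc2)c1` gives the highest of the three numbers, 77.8% in a functional assay on HCC 2998 cells (Homo sapiens) for inhibition, read by sulforhodamine B assay, with a stated time of 48 h, tested at 10 uM; on this read-out higher numbers stand for a weaker effect at the one concentration tested and lower numbers for a stronger effect; compound 2 `COc1cc(Cl)cc(-c2nn(-c3cccc(NC(=O)Nc4ccc(Cl)c(C(F)(F)F)c4)c3)cc2-c2ccncc2)c1` gives 18.1% and compound 3 `COc1cc(Cl)cc(-c2nn(-c3cccc(NC(=O)Nc4cc(C(F)(F)F)cc(C(F)(F)F)c4)c3)cc2-c2ccncc2)c1` gives 9.5%. Compound 4 `COc1cc(Cl)cc(-c2nn(-c3cccc(NC(=O)c4cccc(C(F)(F)F)c4)c3)cc2-c2ccncc2)c1` differs from compound 1 by 3-(trifluoromethyl)phenyl in place of 3,4-dichlorophenyl on a carbonyl carbon. Among the measured compounds shown here, the only measured step from compound 1 is a number 59.7 percentage points lower from compound 1 to compound 2 (beyond the scatter), yet that step also turned the carbonyl-bound aryl into an arylamino, so it bears only loosely here; compound 4 keeps the aryl ring directly on the carbonyl. For the measured compounds named here, no measured step isolates the aryl change alone. Compound 4 is therefore expected to move little, the step being a number 7.8 percentage points lower from compound 1 to compound 4 (within the scatter), likely not beyond the scatter. The estimate for compound 4 is 70%, within 45% to 95%.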

Compound 4, a percentage reported as activity, at one concentration (the size of the read-out at that concentration, not a potency): 54.6%
Compound 4: middle estimate off by 15.4 percentage points, on the high side; measured number inside the range.
By their numbers in this assay, from the lowest: compounds 3 and 2 (each within the scatter of the next); then compound 4; then compound 1.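

With the carbonyl-bound aryl directly attached in both compounds, the ring change alone registers in this assay: a number 23.2 percentage points lower from compound 1 to compound 4 (beyond the scatter) for 3-(trifluoromethyl)phenyl in place of 3,4-dichlorophenyl. Even so, the arylamino of compound 2 remains clearly ahead, the step being a number 36.5 percentage points higher from compound 2 to compound 4 (beyond the scatter) on the same carbonyl carbon, though this step changes the ring substitution as well as the link. No measured evidence accounts for either step. Still open, as far as these compounds go, is how (3-(trifluoromethyl)phenyl)amino on that carbon would read, which would separate the link from the chloro group, and whether a nitrile or a carboxylic acid in place of trifluoromethyl would keep the gain.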